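The compounds below may be only part of what the source reports. "The series", "measured", "known", "first", "only" and "open" are said of these compounds alone.

Of the compounds shown here, three built on one shared core have been tested in a functional assay on HepG2 cells (Homo sapiens) for inhibition, read by MTT assay, with a stated time of 72 h; a lower number here means a stronger inhibitor, a higher number a weaker inhibitor. Compound 1 `Cc1ccccc1-n1cc(COc2cccc(NC(=O)Nc3ccc(Cl)c(C(F)(F)F)c3)c2)nn1` gives 3440 nM. Compound 2 `Cc1cccc(-n2cc(COc3cccc(NC(=O)Nc4ccc(Cl)c(C(F)(F)F)c4)c3)nn2)c1` gives 7270 nM. Compound 3 `CCc1ccccc1-n1cc(COc2cccc(NC(=O)Nc3ccc(Cl)c(C(F)(F)F)c3)c2)nn1` gives 3530 nM, which places it second highest of the three numbers, nearly level with compound 1 and clearly apart from compound 2. The next compound, compound 4 `CC(C)c1ccc(-n2cc(COc3cccc(NC(=O)Nc4ccc(Cl)c(C(F)(F)F)c4)c3)nn2)cc1`, differs from compound 3 in one place: 4-isopropylphenyl in place of 2-ethylphenyl on an aromatic nitrogen. Two kinds of earlier step bear on this. Changing 2-methylphenyl to 3-methylphenyl gave a 2.1-fold higher number from compound 1 to compound 2 (0.32 log units; beyond the scatter), whereas lengthening methyl to ethyl on the chain carbon gave a 1.0-fold higher number from compound 1 to compound 3 (0.01 log units; within the scatter). Read in the other direction, a 2.1-fold lower number from compound 2 to compound 3 (0.31 log units; beyond the scatter). Among these three compounds, then, the arrangement of the alkyl on the phenyl shifted the number modestly, while its length hardly did. Compound 4 carries its alkyl as 4-isopropylphenyl, an arrangement unlike either 2-ethylphenyl or 3-methylphenyl, so a modest step towards a higher number is expected for compound 4, a 1.8-fold higher number from compound 3 to compound 4 (0.27 log units; within the scatter). For compound 4 in this assay the estimate is 6500 nM, with a likely range from 2500 nM to 17000 nM.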

Compound 4, half-maximal inhibitory concentration: 2470 nM
The estimate for compound 4 lay 2.6-fold (0.42 log units) above the measured number, and the stated range ends above it.
By their numbers in this assay, from the lowest: compounds 4, 1 and 3 (each within the scatter of the next); then compound 2.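

In this assay, 4-isopropylphenyl has one more carbon than 2-ethylphenyl, yet the result stays within the scatter, with a 1.4-fold lower number from compound 3 to compound 4 (0.16 log units; within the scatter), and the same holds against 2-methylphenyl, with a 1.4-fold lower number from compound 1 to compound 4 (0.14 log units; within the scatter). Only compound 2 stands apart, with a 2.9-fold lower number from compound 2 to compound 4 (0.47 log units; beyond the scatter), so among these four compounds, 2-methylphenyl, 2-ethylphenyl and 4-isopropylphenyl on the aromatic nitrogen give values that cannot be told apart, and 3-methylphenyl is the one exception. No measurement at hand explains why 3-methylphenyl differs from the other three.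

All four compounds carry a plain alkyl group on the phenyl, so an amine or a carboxylic acid in its place remains an open case. Also open, as far as these compounds go, is how 4-methylphenyl would compare, since it would separate the place of the alkyl from its size.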